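The source may hold more compounds than are shown below. What is called first, only, known or untested is meant among the compounds shown, and "the series" means these compounds.

Of the compounds shown here, three have so far been tested in an ADME assay on Vero cells (Chlorocebus sabaeus) for cytotoxicity; a higher number here means that more compound is tolerated, a lower number that less compound is tolerated. Compound 1 `Fc1ccc(-c2nn3c(NC4CCCC4)cccc3c2-c2ccnc(NC3CCCC3)n2)cc1` gives > 160000 nM, which is a limit of the assay rather than a number. Compound 2 `c1cc(NC2CCCC2)c2nc(-c3ccc(OCC4CC4)cc3)c(-c3ccnc(NC4CCCC4)n3)n2c1` gives > 40000 nM in this assay, again a limit and not a measured number. Compound 3 `COc1cccc(-c2nc3c(Cl)cccn3c2-c2ccnc(NC3CCCC3)n2)c1` also reaches only a limit, > 40000 nM. Compound 2 therefore stands at the limit of > 40000 nM in this assay, at which 2 of the 3 values shown sit, while the remaining value sits at the limit of > 160000 nM in this assay, at which 1 of the 3 values shown sits. None of the three compounds gave a numerical reading, so the values only show that each was tolerated up to the highest concentration tested.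

Compound 4 `C=CCOc1cccc(-c2nc3c(NC4CCCC4)cccn3c2-c2ccnc(NC3CCCC3)n2)c1` has not yet been measured. It differs from compound 2 in one place: 3-(allyloxy)phenyl in place of 4-(cyclopropylmethoxy)phenyl on an aromatic carbon. Among the compounds with values here, no pair of measured compounds differs in a single place, so there is no measured step to lean on. Since the value of compound 2 is a limit, > 40000 nM, the expectation for compound 4 is a step that the limit leaves unreadable from compound 2 to compound 4, which is none beyond the scatter. Compound 4 is therefore expected to be tolerated as well, with an estimated value of 60000 nM and a range from 20000 nM to 160000 nM.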

Compound 4, half-maximal cytotoxic concentration: > 40000 nM
Compound 4 was reported as a limit; the forecaster's own chance of this, stated with the estimate: 80%; the middle value does not contradict the limit.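

In this assay compound 4 gives > 40000 nM, a limit and not a number. Within the data shown here, compound 2 gives > 40000 nM, also a limit, so no step between compound 2 and compound 4 can be read. The compounds shown leave open whether 3-(allyloxy)phenyl in place of 4-(cyclopropylmethoxy)phenyl changes how much compound the cells tolerate.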